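The source may hold more compounds than are shown below. What is called first, only, known or untested is meant among the compounds shown, and "the series" means these compounds.

Compound 1 `CC(C)=CCOc1c(C)c(C)c2c(c1C)CCC(C)(COc1ccc(/C=C3\SC(=O)NC3=O)cc1C)O2` — 27%
Compound 2 `CCOc1cc(/C=C2\SC(=O)NC2=O)ccc1OCC1(C)CCc2c(C)c(OCC=C(C)C)c(C)c(C)c2O1` — 54%
Compound 3 `CC(C)=CCOc1c(C)c(C)c2c(c1C)CCC(C)(COc1ccc(/C=C3\SC(=O)NC3=O)cc1)O2` — 5%

In a functional assay on MCF7 cells (Homo sapiens), tested at 7.5 uM (a higher number here means a weaker effect of the compound at the concentration tested, a lower number a stronger effect), compound 3 gives the lowest of the three numbers, and both other compounds stand beyond the scatter from it: the nearest is compound 1, with the step of a number 22 percentage points lower from compound 1 to compound 3 (beyond the scatter), and the furthest is compound 2, with the step of a number 49 percentage points lower from compound 2 to compound 3 (beyond the scatter). The step of a number 27 percentage points higher from compound 1 to compound 2 (beyond the scatter) shows that the ethoxy group alone lifts the number by a modest amount within this small set.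

Compound 4 `COc1cc(/C=C2\SC(=O)NC2=O)ccc1OCC1(C)CCc2c(C)c(OCC=C(C)C)c(C)c(C)c2O1` differs from compound 3 in one place: methoxy in place of hydrogen on an aromatic carbon. The step that bears on this change most directly is a number 49 percentage points lower from compound 2 to compound 3 (beyond the scatter), since an alkoxy group at the same aromatic carbon is removed there; read the other way, putting an alkoxy group back in raised the number by a large amount. Methoxy is a smaller alkoxy group than ethoxy, so a rise is expected, but probably not the full size seen with ethoxy.

Compound 4 is therefore expected to give a number in this assay well above that of compound 3, estimated at 38% within a range from 18% to 62%, which means an expected step of a number 33 percentage points higher from compound 3 to compound 4 (beyond the scatter).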

Compound 4, a percentage reported as activity, at one concentration (the size of the read-out at that concentration, not a potency): 54%
Beside the measured number, compound 4's estimate is 16 percentage points below it; the range from low to high includes it.
By their numbers in this assay, from the lowest: compound 3; then compound 1; then compounds 2 and 4 (each within the scatter of the next).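

On the aromatic carbon ortho to a large group, methoxy gives a number 49 percentage points higher from compound 3 to compound 4 (beyond the scatter) in this assay, and the comparison with ethoxy gives no change at the digits printed from compound 2 to compound 4 (within the scatter) in the same assay, so the smaller alkoxy group cannot be told apart from the larger one here. The step of a number 27 percentage points higher from compound 1 to compound 4 (beyond the scatter) then places methoxy apart from methyl at this carbon, and among these four compounds the weakest effects at the concentration tested go with the two alkoxy groups, while hydrogen gives the strongest effect and methyl falls in between. No measurement is at hand that would explain why an alkoxy group at this carbon weakens the effect so strongly.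

The compounds shown leave open whether a longer chain such as propoxy, or a hydroxyl group, an amine or a chlorine atom on this carbon, would stay at the level of the two alkoxy groups or come closer to hydrogen. They also leave open whether methoxy would have the same effect on another carbon of this ring, and whether the pattern would hold at a different concentration or in another cell line.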